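Swapping the amide aryl group on a dopamine D3 ligand

This account rests on a few compounds, and the source may have more. Where it says the series, first, only, none or still open, it means among the compounds named here.

Compound 2 `CCCN(CC[C@H]1CC[C@H](NC(=O)c2ccc3ccccc3n2)CC1)[C@H]1CCc2nc(N)sc2C1` was tested in an assay on brain for displacement of a labelled ligand from D(3) dopamine receptor (Rattus norvegicus) (a higher number here means a weaker inhibitor, a lower number a stronger inhibitor), and gives 1.6 nM, the higher of the two measured numbers; compound 1 `CCCN(CC[C@H]1CC[C@H](NC(=O)/C=C/c2cccc(Cl)c2)CC1)[C@H]1CCc2nc(N)sc2C1` gives 1.2 nM, and the two are within the scatter. The change to compound 3 `CCCN(CC[C@H]1CC[C@H](NC(=O)c2cccc(-n3ccnc3)c2)CC1)[C@H]1CCc2nc(N)sc2C1` is 3-(1H-imidazol-1-yl)phenyl in place of quinolin-2-yl on a carbonyl carbon. Among the compounds with values here, one measured step bears on this, a 1.3-fold higher number from compound 1 to compound 2 (0.12 log units; within the scatter), where the group on the same carbonyl carbon was also exchanged. A similar exchange in compound 3 is therefore expected to give no step beyond the scatter, a 1.3-fold higher number from compound 2 to compound 3 (0.10 log units; within the scatter). Compound 3 is estimated at 2 nM, ranging from 0.6 nM to 7 nM.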

Compound 3, inhibition constant: 1.1 nM
For compound 3 the middle estimate is 1.8-fold (0.26 log units) above the measured one; the measured number falls inside the stated range.
By their numbers in this assay, from the lowest: compounds 3, 1 and 2 (each within the scatter of the next).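

On the carbonyl carbon, 3-(1H-imidazol-1-yl)phenyl matches both earlier groups in this assay, with a 1.5-fold lower number from compound 2 to compound 3 (0.16 log units; within the scatter) and a 1.1-fold lower number from compound 1 to compound 3 (0.04 log units; within the scatter). This position therefore now holds three differently shaped aromatic groups, one of them bearing a five-membered aromatic ring, with no step beyond the scatter. Nothing measured here gives a reason for this match.

Since every group shown contains an aromatic ring, it remains open whether a plain methyl group, a longer alkyl chain or a carboxylic acid attached through a chain would keep the number in the same range.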